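The source may report more compounds than this note shows. Statements on the series, on what has been measured and on what is new or still open speak of the compounds shown alone.

Measured so far:
Compound 1, `O=C(Nc1ccc(F)cc1)c1c(NO)cc(-c2ccccc2)oc1=O`. In an ADME assay on Huh-7 cells (Homo sapiens) for cytotoxicity, read by a luciferase reporter and WST assay, with a stated time of 3 days (on this read-out higher numbers stand for lower toxicity in this test and lower numbers for higher toxicity in this test), compound 1 gives > 20000 nM, which is a limit of the assay and not a number.
Compound 2, `O=C(Nc1ccc(Cl)cc1)c1c(NO)cc(-c2ccccc2)oc1=O`. In this assay compound 2 gives > 20000 nM, again a limit and not a number.

Compound 2 thus stands only at a limit: the reading gives no number for it, and the further value shown is a limit as well. Within the data shown here, the one measured step, a step that the two limits leave unreadable from compound 1 to compound 2, cannot be read; the limit of > 20000 nM in this assay, at which 2 of the 2 values shown sit, shows both values sitting at the same limit. Compound 3, `O=C(Nc1ccc(Br)cc1)c1c(NO)cc(-c2ccccc2)oc1=O`, is not yet measured. It differs from compound 2 by bromo in place of chloro on an aromatic carbon. Among the measured compounds shown here, only the step from compound 1 to compound 2 bears on this change, and its size is not readable, so no direction beyond the scatter can be drawn from it; both measured neighbours at the limit suggest that compound 3 will also sit there. The expected step that the limit leaves unreadable from compound 2 to compound 3 is accordingly none beyond the scatter. Compound 3 is estimated at 30000 nM, with a range from 15000 nM to 80000 nM, and most likely reported once more only as a limit.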

Compound 3, half-maximal cytotoxic concentration: > 20000 nM
Compound 3: a limit, no number; the forecaster's own chance of this, stated with the estimate: 80%; the middle value lies beyond the limit too.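

In this assay compound 3 gives > 20000 nM, a limit and not a number. Among these compounds, no step among compound 1, compound 2 and compound 3 can be read: the limit of > 20000 nM in this assay, at which 3 of the 3 values shown sit. Left open is whether the fluoro, chloro and bromo compounds differ at all, and at what concentration any of them becomes toxic to these cells.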